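Working notes: from compound 3 to compound 4

The compounds below may be only part of what the source reports. "The series", "measured", "known", "first", "only" and "open" are said of these compounds alone.

Compound 1 `O=C(NO)c1cccc(/C=C/c2ccnc(-c3ccccc3O)c2)c1`: 3360 nM
Compound 2 `O=C(NO)c1ccc(/C=C/c2ccnc(-c3cccc(O)c3)c2)cc1`: 1610 nM
Compound 3 `O=C(NO)c1ccc(/C=C/c2ccnc(-c3cccc(CO)c3)c2)cc1`: 1700 nM

All three values come from a functional assay on HCT-116 cells (Homo sapiens) for antiproliferative activity, read by CellTiter-Glo, with a stated time of 72 h; on this read-out higher numbers stand for weaker inhibition and lower numbers for stronger inhibition. Compound 3 at 1700 nM lies within the scatter of compound 2 and also within the scatter of compound 1.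

Compound 4 `COc1ccc(-c2cc(/C=C/c3ccc(C(=O)NO)cc3)ccn2)cc1` has not yet been measured. It differs from compound 3 at one place, next to the ring nitrogen, with 4-methoxyphenyl in place of 3-(hydroxymethyl)phenyl (4-methoxyphenyl in place of 3-(hydroxymethyl)phenyl on an aromatic carbon).

Among the measured compounds shown here, only one measured step bears on this place: a 1.1-fold higher number from compound 2 to compound 3 (0.02 log units; within the scatter), with hydroxymethyl in place of hydroxy on an aromatic carbon. That step stays within the scatter. For the measured compounds named here, it is only a partial guide, since no measured compound carries 4-methoxyphenyl and a single step cannot define a trend.

No change beyond the scatter is therefore expected in this assay, and no direction can be favoured. The expected step is a 1.1-fold lower number from compound 3 to compound 4 (0.03 log units; within the scatter). For compound 4 the estimated value is 1600 nM, with an expected range from 650 nM to 3900 nM.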

Compound 4, half-maximal inhibitory concentration: 3560 nM
Beside the measured number, compound 4's estimate is 2.2-fold (0.35 log units) below it, and the stated range covers the measured number.
By their numbers in this assay, from the lowest: compounds 2, 3, 1 and 4 (each within the scatter of the next, the first and the last beyond it).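

In this assay, the aryl group next to the ring nitrogen now gives a step beyond the scatter: 4-methoxyphenyl gives a 2.1-fold higher number from compound 3 to compound 4 (0.32 log units; beyond the scatter) and also a 2.2-fold higher number from compound 2 to compound 4 (0.34 log units; beyond the scatter) against 3-hydroxyphenyl, both modest. The earlier exchange of hydroxy for hydroxymethyl stayed within the scatter, so this position is not indifferent to every change of group, although the shift seen here is small. No measurement shown explains this step.

3-(hydroxymethyl)phenyl and 4-methoxyphenyl match in heavy atoms and hydrogen-bond acceptors but differ in hydrogen-bond donors and in the ring position of their substituent, and the compounds shown do not separate these two differences. Also open, from the compounds shown here alone, is how this position responds to 3-methoxyphenyl, 4-hydroxyphenyl or a group carrying an amine such as aminomethyl.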